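Methylamino Replacing Methylsulfanyl: An Expected Small Step

The compounds below may be only part of what the source reports. "The series", "measured", "known", "first", "only" and "open" are said of these compounds alone.

Compound 1, `CSc1ncnc2c1c(-c1ccccc1)cn2[C@@H]1O[C@H](CO)[C@@H](O)[C@H]1O`: > 20000 nM
Compound 2, `COc1ncnc2c1c(-c1cccs1)cn2[C@@H]1O[C@H](CO)[C@@H](O)[C@H]1O`: 13900 nM

In a functional assay on HepG2 cells (Homo sapiens) for antiproliferative activity, read by XTT assay, with a stated time of 72 h (on this read-out lower numbers stand for stronger inhibition and higher numbers for weaker inhibition), compound 1 gives only a limit, not a number. Among the values shown, compound 1 sits at the limit of > 20000 nM in this assay, at which 1 of the 2 values shown sits. Compound 3, `CNc1ncnc2c1c(-c1ccccc1)cn2[C@@H]1O[C@H](CO)[C@@H](O)[C@H]1O`, differs from compound 1 by methylamino in place of methylsulfanyl on an aromatic carbon. Going by the values given here, no step between measured compounds is known, so only the limit of compound 1 and the weak value of compound 2 frame what can be expected of compound 3. Compound 3 is expected to give about 18000 nM in this assay, between 6000 nM and 40000 nM. That is an expected step of an at least 1.1-fold lower number from compound 1 to compound 3 (0.04 log units; that floor lies within the scatter), within the usual scatter.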

Compound 3, half-maximal inhibitory concentration: > 20000 nM
Compound 3: a limit, no number; the forecaster's own chance of this, stated with the estimate: 50%; middle value at least 1.1-fold (0.04 log units) away from the limit.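

Compound 1 and compound 3 both give only a limit, so no step between them can be read: the limit of > 20000 nM in this assay, at which 2 of the 3 values shown sit.

As far as these compounds go, whether methylamino or methylsulfanyl gives the lower number on the shared core remains open.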